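Replacing a Ring Group with a Small Urea Chain

The compounds below may be only part of what the source reports. "The series", "measured", "known", "first", "only" and "open" are said of these compounds alone.

Compound 2 `COc1ccc(-c2nc(/N=C(\N)[N+]3(C)CCCCC3)sc2-c2ccc(OC)cc2)cc1` has the highest number of the three measured compounds in a functional assay (aorta) with Rattus norvegicus as the target; a lower number here means that less compound is needed, a higher number that more compound is needed for the effect: compound 2 gives 21 uM, while compound 1 `CNC(=N)Nc1nc(-c2ccc(OC)cc2)c(-c2ccc(OC)cc2)s1` gives 1.2 uM and compound 3 `COc1ccc(-c2nc(CNC(=O)c3cccnc3)sc2-c2ccc(OC)cc2)cc1` gives 8.2 uM. Compound 4 `CNC(=O)NCc1nc(-c2ccc(OC)cc2)c(-c2ccc(OC)cc2)s1` carries a different group on the shared core: a group of 6 heavy atoms (3 carbon, 2 nitrogen, 1 oxygen; no ring) in place of a group of 10 heavy atoms (7 carbon, 3 nitrogen; one six-membered non-aromatic ring with 1 hetero atom), on an aromatic carbon. For the measured compounds named here, two measured steps bear on this. an 18-fold higher number from compound 1 to compound 2 (1.24 log units; beyond the scatter) shows that bringing in the ring group raised the number. a 2.6-fold lower number from compound 2 to compound 3 (0.41 log units; beyond the scatter) shows that a chain with a carbonyl brings it part way back. A step of similar direction in this assay is therefore expected: a 3.5-fold lower number from compound 2 to compound 4 (0.54 log units; beyond the scatter). Compound 4 is estimated at 6 uM, within 2 uM to 20 uM.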

Compound 4, concentration for half-maximal effect: 15 uM
Compound 4: middle estimate off by 2.5-fold (0.40 log units), on the low side, within the range that was stated.
By their numbers in this assay, from the lowest: compound 1; then compounds 3, 4 and 2 (each within the scatter of the next, the first and the last beyond it).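

In this assay, the ((methylcarbamoyl)amino)methyl group, with no net charge, cannot be told apart from the ring group of compound 2, which has a net charge of +1 (a 1.4-fold lower number from compound 2 to compound 4 (0.15 log units; within the scatter)), or from the pyridin-3-yl amide chain (a 1.8-fold higher number from compound 3 to compound 4 (0.26 log units; within the scatter)). The group of compound 1 still stands clearly apart from this urea chain (a 13-fold higher number from compound 1 to compound 4 (1.10 log units; beyond the scatter)). Nothing measured here explains these steps. From the compounds shown here alone, it remains open whether a simple amine or a carboxylic acid on this aromatic carbon would match compound 1 or compound 4.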